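The compounds below may be only part of what the source reports. "The series", "measured", "known", "first", "only" and "open" are said of these compounds alone.

Compound 1 (`N#C/C(=C\c1ccccc1OS(=O)(=O)c1ccc([N+](=O)[O-])cc1)C(=O)Nc1nnc(Cc2ccccc2)s1`) carries a plain benzyl group and gives 57% in a functional assay on RS4-11 cells (Homo sapiens) for inhibition, read by CCK-8 assay, with a stated time of 48 h, tested at 20 uM (a lower number here means less inhibition of growth, a higher number more inhibition of growth at the concentration tested), as its reading. Compound 2 (`N#C/C(=C\c1ccccc1OS(=O)(=O)c1ccc([N+](=O)[O-])cc1)C(=O)Nc1nnc(Cc2ccc(F)cc2)s1`) has fluoro in place of hydrogen on an aromatic carbon of that group and gives 55% as its reading. Compound 3 (`N#C/C(=C\c1ccccc1OS(=O)(=O)c1ccc([N+](=O)[O-])cc1)C(=O)Nc1nnc(Cc2ccc(Cl)cc2)s1`) has a 4-chlorobenzyl group instead and gives 66% as its reading. The measurements show a number 11 percentage points higher from compound 2 to compound 3 (beyond the scatter) and a number 9 percentage points higher from compound 1 to compound 3 (within the scatter) so only one of the two gaps around compound 3 is a firm difference.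

Compound 4 (`Cc1ccc(Cc2nnc(NC(=O)/C(C#N)=C/c3ccccc3OS(=O)(=O)c3ccc([N+](=O)[O-])cc3)s2)cc1`) changes 4-chlorobenzyl to 4-methylbenzyl (methyl in place of chloro on an aromatic carbon), which puts methyl in place of chloro on an aromatic carbon, para to a large group. Going by the values given here, no measured step makes this exact swap, and no methyl compound has a reading yet. The nearest guides are the other changes at that carbon, which gave a number 2 percentage points lower from compound 1 to compound 2 (within the scatter) and a number 9 percentage points higher from compound 1 to compound 3 (within the scatter) in the same series. All of these moves are small. The expectation is therefore a slight drift back toward the reading of compound 1 (57%) with no step beyond the scatter in this assay as the likely outcome. The expected step is a number 6 percentage points lower from compound 3 to compound 4 (within the scatter) by this estimate. Compound 4 is estimated at 60% (expected range 48% to 72%).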

Compound 4, percent growth inhibition at one concentration: 64%
For compound 4 the middle estimate is 4 percentage points below the measured one; measured number inside the range.
By their numbers in this assay, from the lowest: compounds 2, 1, 4 and 3 (each within the scatter of the next, the first and the last beyond it).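

In this assay, methyl on this aromatic carbon, para to a large group, reads level with chloro, with a number 2 percentage points lower from compound 3 to compound 4 (within the scatter) as the step, so the reading of compound 3 does not depend on having chlorine at this position. The steps of a number 9 percentage points higher from compound 2 to compound 4 (within the scatter) and a number 7 percentage points higher from compound 1 to compound 4 (within the scatter) are also small, which means compound 4 cannot be told apart from any of the three earlier compounds, and the only firm gap in the set remains the one between the fluoro and chloro compounds. No measurement here explains why these groups give such similar readings.

Hydrogen, fluoro, chloro and methyl are the only groups shown at this carbon, so it remains open whether an amine, a carboxylic acid or a longer chain such as propyl would keep the reading or shift it beyond the scatter. On these data alone, it is also open whether chloro and methyl would still read alike at another carbon of the same ring.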